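The source may report more compounds than this note shows. Statements on the series, on what has been measured and on what is new or still open speak of the compounds shown alone.

Compound 1 `CCN1CCN(c2ccc(S(=O)(=O)Oc3cccc(F)c3)cc2)C1=O` and compound 2 `CCN1CCN(c2ccc(S(=O)(=O)Oc3cccc(Cl)c3)cc2)C1=O` share a core and differ by chloro in place of fluoro on an aromatic carbon. In a functional assay on MCF7 cells (Homo sapiens) for antiproliferative activity, read by sulforhodamine B assay, with a stated time of 48 h (on this read-out lower numbers stand for stronger inhibition and higher numbers for weaker inhibition), compound 1 gives only a limit of the assay, > 100000 nM, at which one of the three values shown sits (the limit of > 100000 nM in this assay, at which 1 of the 3 values shown sits). In this assay compound 2 gives 5400 nM, so that the change made an at least 18-fold lower number from compound 1 to compound 2 (1.26 log units; beyond the scatter). Compound 3 `CCCN1CCN(c2ccc(S(=O)(=O)Oc3cccc(F)c3)cc2)C1=O` differs from compound 1 by methyl in place of hydrogen on a saturated chain carbon, two bonds along the chain from an amide-type nitrogen in a ring; in this assay compound 3 gives 24000 nM, a step of an at least 4.1-fold lower number from compound 1 to compound 3 (0.61 log units; beyond the scatter). Compound 4 `CCCN1CCN(c2ccc(S(=O)(=O)Oc3cccc(Cl)c3)cc2)C1=O` differs from compound 3 by chloro in place of fluoro on an aromatic carbon, the same change as that from compound 1 to compound 2. It is expected to carry over, because the earlier step was an at least 18-fold lower number from compound 1 to compound 2 (1.26 log units; beyond the scatter), though from a starting value that is a number rather than a limit. The step from compound 3 to compound 4 is estimated at a 16-fold lower number from compound 3 to compound 4 (1.20 log units; beyond the scatter). Compound 4 is therefore expected to give about 1500 nM in this assay, within a range from 400 nM to 6000 nM.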

Compound 4, half-maximal inhibitory concentration: 380 nM
Estimate against measurement, compound 4: 3.9-fold (0.60 log units) above, outside the stated range (below it).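

In this assay chloro in place of fluoro gave a 63-fold lower number from compound 3 to compound 4 (1.80 log units; beyond the scatter) and the added methyl on the chain gave a 14-fold lower number from compound 2 to compound 4 (1.15 log units; beyond the scatter) on the chloro core, so both changes lowered the number on each of the two cores shown. For the chloro change this shows that the direction carried over, but not that the size did: the same change on two cores in this assay, an at least 18-fold lower number (1.26 log units; beyond the scatter) from compound 1 to compound 2 and a 63-fold lower number (1.80 log units; beyond the scatter) from compound 3 to compound 4; the limit leaves it open whether they differ.
The same holds for the methyl change: the same change on two cores in this assay, an at least 4.1-fold lower number (0.61 log units; beyond the scatter) from compound 1 to compound 3 and a 14-fold lower number (1.15 log units; beyond the scatter) from compound 2 to compound 4; the limit leaves it open whether they differ.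

The compounds shown leave open whether the same steps would hold for bromo or methoxy in place of chloro, or for a butyl chain or longer on the amide-type nitrogen.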